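Working notes: fluoro to methoxy in the series

This account rests on a few compounds, and the source may have more. Where it says the series, first, only, none or still open, it means among the compounds named here.

Measured in an ADME assay on CCRF-CEM cells (Homo sapiens) for cytotoxicity, with a stated time of 5 days; a higher number here means a weaker inhibitor, a lower number a stronger inhibitor:
- Compound 1 `COc1nc(NC2CC2)c2ncn([C@H]3C[C@H](N=[N+]=[N-])[C@@H](CO)O3)c2n1`: > 100000 nM, a limit.
- Compound 2 `COc1nc(F)nc2c1ncn2[C@H]1C[C@H](N=[N+]=[N-])[C@@H](CO)O1`: > 100000 nM, a limit.
- Compound 3 `CN(C)c1nc(Cl)nc2c1ncn2[C@H]1C[C@H](N=[N+]=[N-])[C@@H](CO)O1`: > 100000 nM, a limit.

Compound 2 has only a limit on record, > 100000 nM, and no number. The other two measured compounds offer no numbers either, and the whole picture in this assay is the limit of > 100000 nM in this assay, at which 3 of the 3 values shown sit. Within the data shown here, no two measured compounds differ in one place only, so no measured step is available as a guide.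

Compound 4 `COc1nc(OC)c2ncn([C@H]3C[C@H](N=[N+]=[N-])[C@@H](CO)O3)c2n1` is still to be measured. It carries methoxy in place of fluoro on an aromatic carbon, between two ring nitrogen atoms: methoxy in place of fluoro on an aromatic carbon. The same shared core already gives a limit with fluoro in compound 2, at > 100000 nM. No step beyond the scatter is expected in this assay, and no direction is favoured. The estimated size of the change is a number no higher from compound 2 to compound 4 (the limit leaves the size open). A report of only a limit is the expected outcome. For compound 4 the estimated value is 100000 nM, with an expected range from 30000 nM to 200000 nM.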

Compound 4, half-maximal inhibitory concentration: > 100000 nM
Compound 4: only a limit was reported; the forecaster's own chance of this, stated with the estimate: 85%; the middle value lies on the limit itself.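

In this assay compound 4 gives > 100000 nM, a limit and not a number. The steps from compound 2 and from compound 1 to compound 4 cannot be read, and the picture is unchanged: the limit of > 100000 nM in this assay, at which 4 of the 4 values shown sit.

The compounds shown leave open whether methoxy in place of fluoro on the shared core makes any difference in this assay.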